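Dimethoxyphenyl for cyanophenyl: cytotoxicity notes on four compounds

The compounds below may be only part of what the source reports. "The series", "measured", "known", "first", "only" and "open" are said of these compounds alone.

Compound 1 `N#Cc1ccc(/C=C2\CN(S(=O)(=O)c3ccc(F)cc3)C/C(=C\c3ccccc3F)C2=O)cc1` and compound 2 `COc1cc(/C=C2\CN(S(=O)(=O)c3ccc(F)cc3)C/C(=C\c3ccccc3F)C2=O)cc(OC)c1` share one core; compound 3 `COc1cc(/C=C2\CN(S(=O)(=O)c3ccc(NC(C)=O)cc3)C/C(=C\c3ccc(C#N)cc3)C2=O)cc(OC)c1OC` carries another, and the difference between the two cores is not broken down here. Compound 4 `COc1cc(/C=C2\CN(S(=O)(=O)c3ccc(NC(C)=O)cc3)C/C(=C\c3cc(OC)c(OC)c(OC)c3)C2=O)cc(OC)c1` has not been measured. In an ADME assay on L02 cells (Homo sapiens) for cytotoxicity, read by MTT assay, with a stated time of 24 h (on this read-out lower numbers stand for stronger inhibition and higher numbers for weaker inhibition), compound 1 gives 21900 nM, compound 2 gives 18500 nM and compound 3 gives 13600 nM. The change from compound 1 to compound 2 is 3,5-dimethoxyphenyl in place of 4-cyanophenyl on a double-bonded chain carbon bound to a double-bonded ring carbon. It made a 1.2-fold lower number from compound 1 to compound 2 (0.07 log units; within the scatter). The change from compound 3 to compound 4 is 3,5-dimethoxyphenyl in place of 4-cyanophenyl on a double-bonded chain carbon bound to a double-bonded ring carbon, the same change at the same place, now on the core of compound 3. The expectation rests on the earlier step of a 1.2-fold lower number from compound 1 to compound 2 (0.07 log units; within the scatter), which stayed within the scatter. The step of a 1.1-fold lower number from compound 3 to compound 4 (0.05 log units; within the scatter) is therefore expected to be small. Compound 4 is estimated at 12000 nM in this assay, between 6000 nM and 25000 nM.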

Compound 4, half-maximal inhibitory concentration: 15900 nM
Compound 4: middle estimate off by 1.3-fold (0.12 log units), on the low side; low and high end bracket the measured number.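

In this assay, putting 3,5-dimethoxyphenyl in place of 4-cyanophenyl on the core of compound 3 gives a 1.2-fold higher number from compound 3 to compound 4 (0.07 log units; within the scatter). Set beside the earlier step, the result carries over in size, with both steps small: the same change on two cores in this assay, a 1.2-fold lower number (0.07 log units; within the scatter) from compound 1 to compound 2 and a 1.2-fold higher number (0.07 log units; within the scatter) from compound 3 to compound 4, 1.4-fold (0.14 log units) apart, within the scatter of two such steps. Within the data shown here, this shows only that the change made no readable difference on these two cores; it gives no direction for the step, no reason for its size and no basis for assuming the same on other cores.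

Still open, from the compounds shown here alone, is whether a phenyl ring bearing an amine or a carboxylic acid at this place would also stay within the scatter in this assay. Also open, going by these compounds, is how this change behaves on a third core.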